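The source may report more compounds than this note shows. Statements on the series, on what has been measured and on what is new or still open speak of the compounds shown alone.

Measured compounds:
Compound 1 `CCC(CC)CNc1c(C(N)=O)cnc2ccc(C#N)cc12`: in an assay on HT-29 cells for inhibition of Serine-protein kinase ATM (Homo sapiens), read by fluorescence, with a stated time of 1 h (on this read-out higher numbers stand for weaker inhibition and lower numbers for stronger inhibition), compound 1 gives 820 nM.
Compound 2 `CCC(CC)CNc1c(C(N)=O)cnc2ccc(-c3cncnc3)cc12`: in this assay compound 2 gives 1840 nM.
Compound 3 `CCC(CC)CNc1c(C(N)=O)cnc2ccc(-c3ccc(C)nc3)cc12`: in this assay compound 3 gives 50 nM.

Compound 3 has the lowest number of the three, that is the strongest inhibition shown here; its nearest neighbour is compound 1, and the step of a 16-fold lower number from compound 1 to compound 3 (1.21 log units; beyond the scatter) is large, as is a 37-fold lower number from compound 2 to compound 3 (1.57 log units; beyond the scatter). Compound 4 `CCC(CC)CNc1c(C(N)=O)cnc2ccc(-c3ccc(CS(C)(=O)=O)nc3)cc12` differs from compound 3 by methylsulfonyl in place of hydrogen on a saturated chain carbon bound to an aromatic carbon; cut one bond further out, the change reads methyl to (methylsulfonyl)methyl. Among the measured compounds shown here, none of the measured steps touches this position: a 2.2-fold higher number from compound 1 to compound 2 (0.35 log units; beyond the scatter), a 16-fold lower number from compound 1 to compound 3 (1.21 log units; beyond the scatter) and a 37-fold lower number from compound 2 to compound 3 (1.57 log units; beyond the scatter) all swap the whole group on the aromatic carbon, and they show that the 6-methylpyridin-3-yl group goes together with the strong inhibition. From the compounds shown here alone, whether a methylsulfonyl group on its methyl keeps this is untested, so no direction can be read from the data. The expectation for compound 4 is therefore a step of about a 1.2-fold higher number from compound 3 to compound 4 (0.08 log units; within the scatter) in this assay, which is not beyond the scatter. Compound 4 is estimated at 60 nM, with a range from 15 nM to 250 nM.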

Compound 4, half-maximal inhibitory concentration: 39 nM
Estimate against measurement, compound 4: 1.5-fold (0.19 log units) above; the measured number falls inside the stated range.
By their numbers in this assay, from the lowest: compounds 4 and 3 (each within the scatter of the next); then compound 1; then compound 2.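

The step of a 1.3-fold lower number from compound 3 to compound 4 (0.11 log units; within the scatter) in this assay shows that compound 3 and compound 4 cannot be told apart, even though compound 4 carries a whole methylsulfonyl group on the saturated chain carbon bound to an aromatic carbon. The earlier steps shown here swapped the entire group on the aromatic carbon, so they said nothing about this outer carbon; this step shows that the strong inhibition seen with the 6-methylpyridin-3-yl group survives the change from methyl to (methylsulfonyl)methyl. No measurement shown here explains why the added group makes no difference beyond the scatter.

The compounds shown leave open whether an amine or a carboxylic acid on this same carbon would fit as well. They also leave open whether a longer chain ending in methylsulfonyl would keep the inhibition.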